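Compound 3 to compound 4: chloro in place of methoxy

The source may hold more compounds than are shown below. What is called first, only, known or untested is meant among the compounds shown, and "the series" means these compounds.

Three compounds have a reading in an ADME assay on HEK293 cells (Homo sapiens) for cytotoxicity, with a stated time of 72 h; a higher number here means that more compound is needed for the effect, a lower number that less compound is needed. Compound 1 (`Cc1cc(NC(=O)Nc2ccc(C)c(Cl)c2)c2ccccc2n1`) gives > 25000 nM, which is a limit and not a number. Compound 2 (`Cc1cc(NC(=O)Nc2ccc(Cl)c(Cl)c2)c2ccccc2n1`) gives > 25000 nM, also a limit. Compound 3 (`COc1ccc(NC(=O)Nc2cc(C)nc3ccccc23)cc1OC`) gives > 25000 nM, again a limit, so its true position is not known. Among the measured compounds shown here, the series so far shows (the limit of > 25000 nM in this assay, at which 3 of the 3 values shown sit).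

Compound 4 (`COc1ccc(NC(=O)Nc2cc(C)nc3ccccc23)cc1Cl`) differs from compound 3 in one place: chloro in place of methoxy on an aromatic carbon.

For the measured compounds named here, the one measured step that bears on this is a step that the two limits leave unreadable from compound 1 to compound 2, where chloro takes the place of methyl on an aromatic carbon. That step offers no size to carry over. No step beyond the scatter is expected in this assay, since compound 2, which carries chloro, gives > 25000 nM, a limit as well. The expected step is a number no higher from compound 3 to compound 4 (the limit leaves the size open), with neither direction favoured. Compound 4 is estimated at 25000 nM, with an expected range of 12000 nM to 40000 nM, and a reading that is again only a limit is the likeliest outcome.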

Compound 4, half-maximal effective concentration: 26000 nM
Compound 4: middle estimate off by 1.0-fold (0.02 log units), on the low side; the range from low to high includes it.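

In this assay no new step can be read: the steps to compound 4 from compound 1, compound 2 and compound 3 each start from a limit, so they have no readable size. Left open is where these three compounds truly stand relative to compound 4, and so whether exchanging chloro, methyl and methoxy shifts the reading at all: the limit of > 25000 nM in this assay, at which 3 of the 4 values shown sit.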